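Cytotoxicity of a hydrazone series: a dibromo-hydroxyphenyl analogue

The compounds below may be only part of what the source reports. "The series", "measured", "known", "first", "only" and "open" are said of these compounds alone.

Measured compounds in an ADME assay on NIH3T3 cells (Mus musculus) for cytotoxicity, read by MTT assay, with a stated time of 24 h; on this read-out higher numbers stand for weaker inhibition and lower numbers for stronger inhibition:
compound 1 `O=C(CSc1nnc(-c2ccncc2)o1)N/N=C/c1ccc(Cl)cc1`: 181000 nM
compound 2 `COc1cccc(/C=N/NC(=O)CSc2nnc(-c3ccncc3)o2)c1`: 179000 nM
compound 3 `O=C(CSc1nnc(-c2ccncc2)o1)N/N=C/c1cc(Br)ccc1O`: 156000 nM

Compound 1 gives the highest of the three numbers, but its nearest neighbour is compound 2, a 1.0-fold lower number from compound 1 to compound 2 (0.00 log units; within the scatter), and its furthest is compound 3, a 1.2-fold lower number from compound 1 to compound 3 (0.06 log units; within the scatter); both steps sit within the scatter, as does a 1.1-fold lower number from compound 2 to compound 3 (0.06 log units; within the scatter). Compound 4 `O=C(CSc1nnc(-c2ccncc2)o1)N/N=C/c1cc(Br)cc(Br)c1O` differs from compound 1 in one place: 3,5-dibromo-2-hydroxyphenyl in place of 4-chlorophenyl on a carbon with a double bond to nitrogen. For the measured compounds named here, the step that bears most on this change is the one to compound 3, which carried the 5-bromo-2-hydroxyphenyl group and stayed within the scatter. The account therefore expects no step beyond the scatter, a 1.1-fold lower number from compound 1 to compound 4 (0.05 log units; within the scatter). Compound 4 is estimated at 160000 nM, in a range from 90000 nM to 280000 nM.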

Compound 4, half-maximal inhibitory concentration: 190000 nM
For compound 4 the middle estimate is 1.2-fold (0.07 log units) below the measured one, and the stated range covers the measured number.
By their numbers in this assay, from the lowest: compounds 3, 2, 1 and 4 (each within the scatter of the next).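

In this assay, bromo in place of hydrogen on an aromatic carbon gives a step within the scatter (a 1.2-fold higher number from compound 3 to compound 4 (0.09 log units; within the scatter)). The 3,5-dibromo-2-hydroxyphenyl group, the largest of the four groups by heavy atoms where counted, also stays within the scatter of both 4-chlorophenyl (a 1.0-fold higher number from compound 1 to compound 4 (0.02 log units; within the scatter)) and 3-methoxyphenyl (a 1.1-fold higher number from compound 2 to compound 4 (0.03 log units; within the scatter)). On a carbon with a double bond to nitrogen, this assay therefore separates none of the four compounds shown. Going by these compounds, whether an amine or a carboxylic acid on this ring, or a change to the shared core, would move the number beyond the scatter stays open. No measurement at hand explains why these groups stay within the scatter.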